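From 4,4,4-trifluorobutyl to 3-cyanopropyl

A few compounds are considered here, and "the series" means these few. Any claim that something is new, unique, unknown or untested is made for them only; others in the source may bear on it.

Compound 1 `CCCn1nc(C(=O)N[C@H]2COc3ccccc3N(C)C2=S)nc1Cc1ccccc1` and compound 2 `CN1C(=S)[C@@H](NC(=O)c2nc(Cc3ccccc3)n(CCCC(F)(F)F)n2)COc2ccccc21` have been measured, while compound 3 `CN1C(=S)[C@@H](NC(=O)c2nc(Cc3ccccc3)n(CCCC#N)n2)COc2ccccc21` has not. In a toxicity assay on HT-29 cells (Homo sapiens) for cytotoxicity (on this read-out lower numbers stand for higher toxicity in this test and higher numbers for lower toxicity in this test), compound 1 gives > 100000 nM, which is a limit and not a number. In this assay compound 2 gives > 100000 nM, which is also a limit. The position of compound 2 is therefore (the limit of > 100000 nM in this assay, at which 2 of the 2 values shown sit).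

Compound 3 carries cyano in place of trifluoromethyl on a saturated chain carbon, three bonds along the chain from an aromatic nitrogen. Among the measured compounds shown here, the one measured step bearing on this chain is a step that the two limits leave unreadable from compound 1 to compound 2. It offers no size to carry forward, so no change beyond the scatter is expected in this assay, and no direction is expected either. The expected step is a number no higher from compound 2 to compound 3 (the limit leaves the size open). A further report as a limit is the likeliest outcome. For compound 3 the estimate is 100000 nM, with an expected range of 40000 nM to 250000 nM.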

Compound 3, half-maximal cytotoxic concentration: > 100000 nM
Compound 3: no number, only a limit; the forecaster's own chance of this, stated with the estimate: 85%; the middle value lies on the limit itself.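

In this assay, among the compounds shown here, compound 1, compound 2 and compound 3 are all reported only as limits, so no step among them can be read. Left open is whether the three chains on the shared core differ at all in this read-out: the limit of > 100000 nM in this assay, at which 3 of the 3 values shown sit.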